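Sulfamoylamino to methylated sulfonamide side chain: compound 3

The compounds below may be only part of what the source reports. "The series", "measured", "known", "first", "only" and "open" are said of these compounds alone.

In an in vivo ADME assay on the whole organism for pharmacokinetics, with Rattus norvegicus as the target, at a dose of 5 mg/kg by the oral route (a lower number here means that a smaller share of the oral dose reaches the circulation, a higher number that a larger share of the oral dose reaches the circulation), compound 1 `Cc1cc(CN2C(=O)C(C3=NS(=O)(=O)c4c(CNS(C)(=O)=O)cccc43)=C(O)[C@@H]2C(C)(C)C)ccc1F` gives 17% and compound 2 `Cc1cc(CN2C(=O)C(C3=NS(=O)(=O)c4c(CNS(N)(=O)=O)cccc43)=C(O)[C@@H]2C(C)(C)C)ccc1F` gives 8.2% as its reading, so the two stand within the scatter of each other. Compound 3 `Cc1cc(CN2C(=O)C(C3=NS(=O)(=O)c4c(CN(C)S(C)(=O)=O)cccc43)=C(O)[C@@H]2C(C)(C)C)ccc1F` is not yet measured. It is reached from compound 2 by methyl(methylsulfonyl)amino in place of sulfamoylamino on a saturated chain carbon bound to an aromatic carbon and so has methyl on the sulfonyl sulfur again, as compound 1 does. Going by the values given here, the one measured step bearing on this is a number 8.8 percentage points lower from compound 1 to compound 2 (within the scatter) for amino in place of methyl on a sulfonyl sulfur. Read backwards, it points to a small upward move at most. Among the compounds with values here, no measured compound carries methyl(methylsulfonyl)amino, so that part of the change has no data behind it. The expected step is a number 9.8 percentage points higher from compound 2 to compound 3 (within the scatter) in this assay and is not expected to clear the scatter clearly. Compound 3 is estimated at 18% with a range from 7% to 38% for now.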

Compound 3, oral bioavailability: 24%
Estimate against measurement, compound 3: 6 percentage points below, within the range that was stated.
By their numbers in this assay, from the lowest: compounds 2, 1 and 3 (each within the scatter of the next, the first and the last beyond it).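

In this assay, going by these compounds alone, the replacement of sulfamoylamino by methyl(methylsulfonyl)amino on a saturated chain carbon bound to an aromatic carbon gives a number 15.8 percentage points higher from compound 2 to compound 3 (beyond the scatter) and is the only step so far that clears the scatter. Methyl in place of hydrogen on a sulfonamide nitrogen gives a number 7 percentage points higher from compound 1 to compound 3 (within the scatter) and so cannot be told apart from no change on its own, which means this position shows a step beyond the scatter only when the sulfonyl sulfur and the sulfonamide nitrogen both change. No measurement on hand offers an explanation for this step.

How much of the step belongs to each of the two methyl groups stays unresolved. Also open, going by these compounds, is how ethyl on the sulfonamide nitrogen, or a longer chain on the sulfonyl sulfur, would read in this assay at this place.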